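The source may report more compounds than this note shows. Statements on the series, on what has been measured and on what is new or still open speak of the compounds shown alone.

Measured compounds:
compound 1 `COC/C(=C(/c1ccc(/C=C/C(=O)O)cc1)c1ccc2[nH]ncc2c1)c1ccccc1`: 88 nM
compound 2 `CC/C(=C(/c1ccc(/C=C/C(=O)O)cc1)c1ccc2[nH]nc(C)c2c1)c1ccccc1`: > 1000 nM

In a functional assay on MCF7 cells (Homo sapiens) for cytotoxicity, read by CellTiter-Glo, with a stated time of 5 days (on this read-out higher numbers stand for weaker inhibition and lower numbers for stronger inhibition), compound 1 gives 88 nM. For compound 2 the read-out is a limit rather than a number, > 1000 nM. This reflects (the limit of > 1000 nM in this assay, at which 1 of the 2 values shown sits). For the measured compounds named here, no step between measured compounds can be counted here.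

Compound 3 `CC/C(=C(/c1ccc(/C=C/C(=O)O)cc1)c1ccc2[nH]nc(Cl)c2c1)c1ccccc1` differs from compound 2 by chloro in place of methyl on an aromatic carbon. With compound 2 sitting at the limit, no direction for this change can be read from the shown values; the expected step that the limit leaves unreadable from compound 2 to compound 3 is taken as none beyond the usual scatter. Compound 3 is therefore estimated at 1500 nM, with a range from 400 nM to 6000 nM, and a limit read-out remains quite possible.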

Compound 3, half-maximal inhibitory concentration: 284 nM
The estimate for compound 3 lay 5.3-fold (0.72 log units) above the measured number; the measured number lies below the stated range.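

Chloro in place of methyl, 3-methyl-1H-indazol-5-yl to 3-chloro-1H-indazol-5-yl, gives in this assay an at least 3.5-fold lower number from compound 2 to compound 3 (0.54 log units; beyond the scatter), which shows that this aromatic carbon next to the ring nitrogen responds to the group it carries. For compound 2 the read-out is a limit, > 1000 nM. The full size of the step stays unknown: the limit of > 1000 nM in this assay, at which 1 of the 3 values shown sits.

Compound 1 and compound 3 differ in more than one place and give no comparison of chloro with the bare ring carbon. Going by these compounds, how bromo, a nitrile or an amine on this carbon would read remains open.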